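Dichlorophenyl in Place of Naphthyl on an Acetylated Sugar

A few compounds are considered here, and "the series" means these few. Any claim that something is new, unique, unknown or untested is made for them only; others in the source may bear on it.

Three compounds share one core, an acetylated sugar carrying an unsaturated ketone chain that ends in an aromatic group. Compound 1 `CC(=O)OC[C@H]1O[C@@H](CC(=O)/C=C/c2cc(Cl)cc(Cl)c2)[C@H](OC(C)=O)[C@@H](OC(C)=O)[C@@H]1OC(C)=O` carries a 3,5-dichlorophenyl group there; compound 2 `CC(=O)OC[C@H]1O[C@@H](CC(=O)/C=C/c2cccs2)[C@H](OC(C)=O)[C@@H](OC(C)=O)[C@@H]1OC(C)=O` a thiophene; compound 3 `CC(=O)OC[C@H]1O[C@@H](CC(=O)/C=C/c2cccc3ccccc23)[C@H](OC(C)=O)[C@@H](OC(C)=O)[C@@H]1OC(C)=O` a naphthalen-1-yl group. In an ADME assay on cells (Epithelial cell, Homo sapiens) for cytotoxicity, read by MTT assay, with a stated time of 24 h (a lower number here means that less compound is tolerated, a higher number that more compound is tolerated), compound 1 gives 32.9 nM. For compound 2 this assay gives "not determined" (no result reported). For compound 3 this assay likewise gives "not determined" (no result reported), so compound 3 stands without any number, as does one further compound of the set.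

Compound 4 `CC(=O)OC[C@H]1O[C@@H](CC(=O)/C=C/c2ccc(Cl)c(Cl)c2)[C@H](OC(C)=O)[C@@H](OC(C)=O)[C@@H]1OC(C)=O` is the next step from compound 3. The change is 3,4-dichlorophenyl in place of naphthalen-1-yl on a double-bonded chain carbon bound to a double-bonded chain carbon. Among the compounds with values here, with no number for compound 3, neither the size nor the direction of this step in this assay can be read from what is known; the only anchor is compound 1, whose group differs from that of compound 4 only in the placing of its two chlorine atoms. Because compound 1 gives 32.9 nM, compound 4 is expected to sit close to it, at an estimated 35 nM, most likely between 12 nM and 100 nM.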

Compound 4, half-maximal cytotoxic concentration: 25.8 nM
Estimate against measurement, compound 4: 1.4-fold (0.13 log units) above; low and high end bracket the measured number.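

Within the data shown here, compound 4 supplies the first comparison at this position. With 3,4-dichlorophenyl in place of 3,5-dichlorophenyl on a double-bonded chain carbon bound to a double-bonded chain carbon, this assay shows a 1.3-fold lower number from compound 1 to compound 4 (0.11 log units; within the scatter), so the two placings of the chlorine atoms cannot be told apart in this measurement. The step from compound 3 to compound 4 cannot be read, as compound 3 has no number, and nothing can therefore be said about naphthalen-1-yl against either dichlorophenyl group. The data shown offer no explanation for this result.

From the compounds shown here alone, both compounds with a number carry two chlorine atoms on a phenyl ring, and compound 2, the thiophene, has no number, so the effect of any other kind of aromatic group in this assay remains unknown. Going by these compounds, it also remains open whether a phenyl ring with a single chlorine atom, a methoxy group or an amine would give a number like those of compound 1 and compound 4, or whether one clearly apart from them would appear.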